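The source may hold more compounds than are shown below. What is called first, only, known or untested is meant among the compounds shown, and "the series" means these compounds.

Working notes on the series. Compound 1 `O=S(=O)(CC1=NCCS1)c1n[nH]cc1-c1ccccc1` is recorded in a functional assay, tested at 100 ug/mL (a lower number here means a weaker effect, a higher number a stronger effect of the compound at the concentration tested), as "not active" (no number reported), with no number reported for compound 1. Compound 2 `O=S(=O)(CC1=NCCO1)c1n[nH]cc1-c1ccccc1` is the reference here; in this assay compound 2 gives 58.5%. Compound 3 `O=S(=O)(CC1=NCCO1)C1C(c2ccccc2)=NOC1c1ccccc1`, which carries the same sulfonyl-linked side chain on a different core, gives 56.6% in this assay, and the two numbers lie within the scatter of each other, so no order between compound 2 and compound 3 is claimed. Compound 4 `Cc1ccc(-c2c[nH]nc2S(=O)(=O)CC2=NCCO2)cc1` is the next entry and has not yet been run in this assay. It differs from compound 2 by methyl in place of hydrogen on an aromatic carbon. For the measured compounds named here, with no measured step of this kind available, the expectation is for compound 4 to land close to compound 2, and the step of a number 1.5 percentage points lower from compound 2 to compound 4 (within the scatter) is estimated to stay within the scatter. Compound 4 is expected to give 57% in this assay, with a range from 40% to 74%.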

Compound 4, a percentage reported as activity, at one concentration (the size of the read-out at that concentration, not a potency): 65.5%
Compound 4: middle estimate off by 8.5 percentage points, on the low side; the range from low to high includes it.
By their numbers in this assay, from the lowest: compounds 3, 2 and 4 (each within the scatter of the next).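

Phenyl to 4-methylphenyl is the first change in the series made in one place only, and in this assay it gives a number 7 percentage points higher from compound 2 to compound 4 (within the scatter) and so shows that methyl is tolerated on this aromatic carbon, para to a large group. The step supports no order between the two compounds. No available data bear on what lies behind this result.

Open, on these data alone, is whether a methoxy group, a chlorine atom or an amine at this place keeps the read-out within the scatter of compound 2. Also open, as far as these compounds go, is whether methyl gives a similar step on the core of compound 3.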